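The source may hold more compounds than are shown below. What is called first, only, known or untested is meant among the compounds shown, and "the series" means these compounds.

Working notes on the sulfonyl anilide series.

Compound 1 `CC(O)(C(=O)Nc1ccc(S(=O)(=O)c2ccccc2)c(C#N)c1)C(F)(F)F` gives 3800 nM in a functional assay (Cavia porcellus) with sulfonylurea receptors; K-ATP channels (Homo sapiens) as the target; on this read-out lower numbers stand for stronger inhibition and higher numbers for weaker inhibition. Compound 3 `Cc1cc(NC(=O)C(C)(O)C(F)(F)F)ccc1S(=O)(=O)c1ccccc1` gives 1600 nM in this assay. Among the compounds with values here, the one single-site step measured so far, a 2.4-fold lower number from compound 1 to compound 3 (0.38 log units; beyond the scatter), with methyl in place of cyano on an aromatic carbon, lowers the number modestly and beyond the scatter.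

For compound 2 `CC(O)(C(=O)Nc1ccc(S(=O)(=O)c2ccc(C#N)cc2)cc1)C(F)(F)F`, this assay reports only a limit, > 30000 nM, so where it stands among the measured compounds cannot be placed more closely than that; it is the only one of the three at that limit (the limit of > 30000 nM in this assay, at which 1 of the 3 values shown sits).

Compound 4 `Cc1cccc(S(=O)(=O)c2ccc(NC(=O)C(C)(O)C(F)(F)F)cc2)c1` is not yet measured. It differs from compound 2 in one place: 3-methylphenyl in place of 4-cyanophenyl on a sulfonyl sulfur. Within the data shown here, the measured step between compound 1 and compound 3 concerns the other aromatic ring and is the only guide to a methyl-for-cyano exchange. Compound 1 and compound 3, both carrying an unsubstituted phenyl on the sulfonyl sulfur, sit at numbers well inside the measurable range, whereas compound 2 with the 4-cyanophenyl does not. The expectation for compound 4 is therefore a lower number than the limit of compound 2, a step of an at least 10-fold lower number from compound 2 to compound 4 (1.00 log units; beyond the scatter) in this assay. Compound 4 is estimated at 3000 nM, with a range from 800 nM to 15000 nM.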

Compound 4, half-maximal inhibitory concentration: 2200 nM
The estimate for compound 4 lay 1.4-fold (0.13 log units) above the measured number, and the stated range covers the measured number.
By their numbers in this assay, from the lowest: compounds 3, 4 and 1 (each within the scatter of the next, the first and the last beyond it). At a limit, above all of these: compound 2.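

In this assay, the sulfonyl sulfur position proves highly sensitive to this exchange: 3-methylphenyl in place of 4-cyanophenyl gives an at least 13-fold lower number from compound 2 to compound 4 (1.13 log units; beyond the scatter), a large step that brings the series back into the measurable range. Compound 2 stands at a limit of the assay and not at a number: the limit of > 30000 nM in this assay, at which 1 of the 4 values shown sits. The earlier step, a 2.4-fold lower number from compound 1 to compound 3 (0.38 log units; beyond the scatter), was modest and concerned the other aromatic ring, whereas this one changes both the group and its printed position, so the two exchanges are not equivalent.

The compounds shown cannot separate the loss of the nitrile from the change of position; 4-methylphenyl and 3-cyanophenyl on the sulfonyl sulfur would address that. On these data alone, how an amine or a carboxylic acid on this aromatic ring would read in this assay also remains open.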